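Alpha-Methyl on the Acid Chain of Compound 1

The source may report more compounds than this note shows. Statements on the series, on what has been measured and on what is new or still open speak of the compounds shown alone.

Compound 1 `O=C(O)Cn1nc(Cn2cc3cc(OCC4CC4)c(Cl)cc3n2)c2ccccc2c1=O` carries a carboxymethyl chain on the ring nitrogen of its core. In a functional assay on HFL1 cells for antagonist activity at sphingosine 1-phosphate receptor 2 (Homo sapiens), read by ELISA, with a stated time of 24 h (on this read-out higher numbers stand for weaker inhibition and lower numbers for stronger inhibition), compound 1 gives 8.1 nM, the lowest of the two numbers shown. Within the data shown here, the only other measured compound is compound 2 `COC(C(=O)O)c1nn(Cc2cn3cc(OCC4CC4)c(Cl)cc3n2)c2ccccc2c1=O`, which differs in both its core and its acid chain; in this assay compound 2 gives 94 nM, a weaker result that lies beyond the scatter, but no single-change step links it to compound 1.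

Compound 3 `C[C@H](C(=O)O)n1nc(Cn2cc3cc(OCC4CC4)c(Cl)cc3n2)c2ccccc2c1=O` arises from compound 1 by a change of methyl in place of hydrogen on a saturated chain carbon bound to an aromatic nitrogen and a carbonyl carbon. Among the measured compounds shown here, there is no measured pair here that isolates such a change, so the expectation rests on compound 1 alone. A methyl of this kind is expected to shift this assay only slightly, with a step of about a 1.5-fold higher number from compound 1 to compound 3 (0.17 log units; within the scatter) from compound 1 to compound 3. Compound 3 is therefore estimated at 12 nM, within the range 4 nM to 40 nM.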

Compound 3, half-maximal inhibitory concentration: 3.5 nM
The estimate for compound 3 lay 3.4-fold (0.54 log units) above the measured number; measured number below the stated range.
By their numbers in this assay, from the lowest: compound 3; then compound 1; then compound 2.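

In this assay, the saturated chain carbon bound to an aromatic nitrogen and a carbonyl carbon takes a methyl in place of hydrogen with a gain rather than a loss: going from carboxymethyl to 1-carboxyethyl gives a 2.3-fold lower number from compound 1 to compound 3 (0.36 log units; beyond the scatter), a modest but real step toward stronger inhibition. Among these compounds, no earlier pair could isolate this position, as compound 2 differs from compound 1 in both its core and its acid chain. No measurement shown here offers an explanation for the step.

The compounds shown leave open whether an ethyl group, a hydroxyl group or a second methyl on this same carbon would lower the number further or raise it. They also leave open how the mirror-image form of compound 3 would compare, as only one arrangement of the methyl appears here.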